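Pyrazoline-coumarin series: tosyl in place of chloroacetyl

The compounds below may be only part of what the source reports. "The series", "measured", "known", "first", "only" and "open" are said of these compounds alone.

Of the compounds shown here, two carry a number so far. Compound 1 `COc1ccccc1C1CC(C)=NN1C(=O)CN1CCC(OC)CC1` is one; in a functional assay on MGC-803 cells (Homo sapiens) for cytotoxicity, read by MTT assay, with a stated time of 48 h (on this read-out lower numbers stand for stronger inhibition and higher numbers for weaker inhibition), compound 1 gives 9550 nM. Compound 2 `O=C(CCl)N1N=C(c2cc3ccccc3oc2=O)CC1c1ccccc1` is the other; in this assay compound 2 gives 2020 nM, the lowest of the two numbers, with compound 1 standing a step higher that lies beyond the scatter. Within the data shown here, no pair of measured compounds differs in one place, so no single change has a measured size yet.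

Compound 3 `Cc1ccc(S(=O)(=O)N2N=C(c3cc4ccccc4oc3=O)CC2c2ccccc2)cc1` is not yet measured. It differs from compound 2 by (4-methylphenyl)sulfonyl in place of (chloromethyl)carbonyl on an amine nitrogen in a ring. Nothing measured in the series speaks to this exchange. The expected step of a 2.0-fold higher number from compound 2 to compound 3 (0.30 log units; within the scatter) is a modest rise, not clearly beyond the scatter. Compound 3 is therefore estimated at 4000 nM in this assay, within 1200 nM to 13000 nM.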

Compound 3, half-maximal inhibitory concentration: 50200 nM
Beside the measured number, compound 3's estimate is 13-fold (1.10 log units) below it, outside the stated range (above it).
By their numbers in this assay, from the lowest: compound 2; then compound 1; then compound 3.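

The amine nitrogen in a ring now has its first measured single change: in this assay there is a 25-fold higher number from compound 2 to compound 3 (1.40 log units; beyond the scatter) with (4-methylphenyl)sulfonyl in place of (chloromethyl)carbonyl. The number at this position therefore responds strongly to the group it carries, and of these two groups (chloromethyl)carbonyl goes with the lower number. No measurement at hand accounts for the size of this step.

From the compounds shown here alone, the exchange alters the chlorine, the carbonyl link and the aromatic ring in one move, so which of these parts goes with the rise remains open. Acetyl, benzoyl or methylsulfonyl on the same nitrogen would separate those parts, and whether any group there gives a lower number than (chloromethyl)carbonyl is also unsettled.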